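The source may hold more compounds than are shown below. What is called first, only, known or untested is meant among the compounds shown, and "the series" means these compounds.

Going by the values given here, compound 2 `Nc1nc(-c2cccc(O)c2)nc2sc(-c3ccccc3)nc12` gives 190 nM in an assay on CHO cells for displacement of a labelled ligand from adenosine receptor A3 (Homo sapiens), read by scintillation counting, with a stated time of 3 h (a higher number here means a weaker inhibitor, a lower number a stronger inhibitor), the higher of the two numbers measured; its nearest neighbour is compound 1 `Nc1nc(-c2ccccc2)nc2sc(-c3ccccc3)nc12` with 84 nM, and the only measured step is a 2.3-fold higher number from compound 1 to compound 2 (0.35 log units; beyond the scatter), a hydroxy in place of hydrogen on an aromatic carbon. Compound 3 `Nc1nc(-c2ccco2)nc2sc(-c3ccccc3)nc12` is not yet measured; it differs from compound 2 in that (furan-2-yl in place of 3-hydroxyphenyl on an aromatic carbon). That step removes the hydroxy whose arrival made the number rise, but it also swaps the ring itself, so the expectation rests on that single step only. Compound 3 is expected to give 120 nM in this assay, within 40 nM to 400 nM, which would mean an expected step of a 1.6-fold lower number from compound 2 to compound 3 (0.20 log units; within the scatter).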

Compound 3, inhibition constant: 2.8 nM
Estimate against measurement, compound 3: 43-fold (1.63 log units) above; measured number outside the range, below it.
By their numbers in this assay, from the lowest: compound 3; then compound 1; then compound 2.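

In this assay the ring itself at this position, between two ring nitrogen atoms, proves to count for much more than the hydroxy did. Furan-2-yl in place of 3-hydroxyphenyl gives a 68-fold lower number from compound 2 to compound 3 (1.83 log units; beyond the scatter) and furan-2-yl in place of phenyl gives a 30-fold lower number from compound 1 to compound 3 (1.48 log units; beyond the scatter), so the change reaches well past the modest 2.3-fold higher number from compound 1 to compound 2 (0.35 log units; beyond the scatter). Nothing measured here accounts for this large change. Still open, going by these compounds, is whether the ring oxygen or the smaller ring matters, which thiophen-2-yl at this place could separate.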